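This account rests on a few compounds, and the source may have more. Where it says the series, first, only, none or still open, it means among the compounds named here.

Measured compounds:
compound 1, `CCCn1ccc2cc(OCCCc3cccnc3)cc(Cl)c2c1=O`, in a functional assay on CHO cells for agonist activity at metabotropic glutamate receptor 2 (Homo sapiens), read by GTPgammaS binding (on this read-out higher numbers stand for larger maximal responses and lower numbers for smaller maximal responses), compound 1 gives 75%
compound 2, `CCCn1ccc2cc(-c3ccc(OC)cc3)cc(Cl)c2c1=O`, in this assay compound 2 gives 136%

Within the data shown here, compound 2 stands at the higher of the two maximal responses seen so far; compound 1, the only other compound with a number, gives a maximal response that sits well below it, and the gap between the two lies beyond the usual scatter of repeated measurements. Among the measured compounds shown here, no pair of measured compounds differs in a single place, so no step between measured compounds can be read off directly.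

Compound 3, `CCCn1ccc2cc(-c3ccc(OCc4ccc(Cl)nc4)cc3)cc(Cl)c2c1=O`, has not yet been tested. It departs from compound 2 in one place: 6-chloropyridin-3-yl in place of hydrogen on a saturated chain carbon bound to an oxygen on an aromatic ring. Put another way, the methoxy of compound 2 becomes a (6-chloropyridin-3-yl)methoxy in compound 3.

For the measured compounds named here, nothing among the measured compounds shows how this change plays out in this assay. A step from compound 2 to compound 3 of modest size is expected, with a somewhat downward lean, and it may well stay within the scatter: a number 11 percentage points lower from compound 2 to compound 3 (beyond the scatter). On that basis compound 3 is estimated to reach 125% in this assay, within a range from 75% to 170%.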

Compound 3, largest response reached (Emax), in percent of the reference or control that the assay uses: 81%
Compound 3: the middle estimate sits 44 percentage points above what was measured; measured number inside the range.
By their numbers in this assay, from the lowest: compounds 1 and 3 (each within the scatter of the next); then compound 2.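

Among these compounds, replacing the methoxy of compound 2 with a (6-chloropyridin-3-yl)methoxy gives the only step that can be read at this place, and in this assay it is large, with a number 55 percentage points lower from compound 2 to compound 3 (beyond the scatter) as the result. This shows that the place, on a saturated chain carbon bound to an oxygen on an aromatic ring, is not indifferent to what it carries: with 6-chloropyridin-3-yl in place of hydrogen the maximal response falls, though compound 3 still gives 81% as a clear response. No measurement at hand accounts for this fall, and its cause stays unexplained.

On these data alone, it remains open whether a plain benzyloxy, a pyridin-3-ylmethoxy without the chlorine, or a simple ethoxy at this place would give a response nearer to that of compound 2 or to that of compound 3, and so whether the chlorine, the pyridine ring or the extra length goes with the fall. A single step also leaves open whether the same change would lower the response to a similar extent with a group other than propyl on the nitrogen of the shared core.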